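The compounds below may be only part of what the source reports. "The series", "measured", "known", "first", "only" and "open" are said of these compounds alone.

Measured so far in an assay on cells for activation of probable G-protein coupled receptor 34 (Mus musculus), with a stated time of 1 h; a higher number here means a larger maximal response, a lower number a smaller maximal response:

- compound 1, `N[C@@H](COP(=O)(O)OCCCOC(=O)CCc1ccccc1OCc1cccc(Cc2ccccc2)c1)C(=O)O`: 0.077
- compound 2, `N[C@@H](COP(=O)(O)OCCCOC(=O)CCc1ccccc1OCc1cccc(OC2CCCCC2)c1)C(=O)O`: 0.11
- compound 3, `Cc1cccc(Oc2cccc(COc3ccccc3CCC(=O)OCCCOP(=O)(O)OC[C@H](N)C(=O)O)c2)c1`: 0.29

Compound 3 holds the highest of the three numbers. Against compound 2 its step is a number 0.18 higher from compound 2 to compound 3 (beyond the scatter), a modest gain that goes beyond the scatter; against compound 1 it is a number 0.21 higher from compound 1 to compound 3 (beyond the scatter), likewise beyond the scatter. The remaining step, a number 0.033 higher from compound 1 to compound 2 (within the scatter), stays within the scatter, so nothing separates compound 1 from compound 2.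

Compound 4, `N[C@@H](COP(=O)(O)OCCCOC(=O)CCc1ccccc1OCc1cccc(Oc2ccccc2Cl)c1)C(=O)O`, is the next compound. Its change from compound 3 is 2-chlorophenyl in place of 3-methylphenyl on an oxygen on an aromatic ring. Within the data shown here, no measured step swaps one aryl group for another on that oxygen; the two steps that touch this part of the molecule, a number 0.21 higher from compound 1 to compound 3 (beyond the scatter) and a number 0.18 higher from compound 2 to compound 3 (beyond the scatter), both bring an aryloxy group in and both raise the response modestly. Among the measured compounds shown here, compound 4 keeps an aryloxy group at the same place, so the base of compound 3 is the natural reference, and no step in the data argues for a shift beyond the scatter in either direction. The expected step is therefore a number 0.030 lower from compound 3 to compound 4 (within the scatter).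

For compound 4 the estimate in this assay is 0.26, within a range of 0.13 to 0.4.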

Compound 4, intrinsic activity: the largest response reached, as a fraction of the reference agonist's: 0.069
Estimate against measurement, compound 4: 0.19 above; the measured number lies below the stated range.
By their numbers in this assay, from the lowest: compounds 4, 1 and 2 (each within the scatter of the next); then compound 3.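

In this assay, an aryl group on this oxygen is not enough on its own for the larger maximal response: a number 0.22 lower from compound 3 to compound 4 (beyond the scatter), even though 3-methylphenyl and 2-chlorophenyl both have 7 heavy atoms and one six-membered aromatic ring. With 2-chlorophenoxy in place, the response returns to the level of the benzyl and cyclohexyloxy analogues, as a number 0.0080 lower from compound 1 to compound 4 (within the scatter) and a number 0.041 lower from compound 2 to compound 4 (within the scatter) show. The gain seen with 3-methylphenoxy therefore belongs, among the compounds shown, to that group alone and not to aryloxy groups as a class, with 2-chlorophenoxy standing against any such general reading.

No measurement at hand bears on why these two aryl groups differ. On these data alone, the swap changes both the substituent and its numbered place on the ring, so it remains open whether the chlorine, its place or the loss of the methyl sets the response, and an unsubstituted phenyl on the same oxygen would give the missing reference for both aryl groups.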